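The source may hold more compounds than are shown below. What is called first, only, known or untested is meant among the compounds shown, and "the series" means these compounds.

Three analogues sharing one core have been measured in a functional assay on HCC 2998 cells (Homo sapiens) for cytotoxicity, read by sulforhodamine B assay, with a stated time of 48 h, tested at 10 uM; a lower number here means a stronger effect, a higher number a weaker effect of the compound at the concentration tested. Compound 1 (`COc1cc(-c2cc(/C=C/C(=O)c3ccc(N)cc3)[nH]n2)cc(OC)c1OC`) gives -86%, and compound 2 (`COc1ccc(-c2cc(/C=C/C(=O)c3ccc(OC)c(OC)c3)[nH]n2)cc1`) gives -68%. Compound 3 (`COc1cc(-c2cc(/C=C/C(=O)c3ccc(Cl)c(Cl)c3)[nH]n2)cc(OC)c1OC`) gives 49%, the highest of the three numbers, standing beyond the scatter above both compound 2 and compound 1. Going by the values given here, the single step that reaches it, a number 135 percentage points higher from compound 1 to compound 3 (beyond the scatter), shows how strongly the aryl group on the carbonyl carbon moves this assay.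

Compound 4 (`COc1cc(-c2cc(/C=C/C(=O)c3ccc(F)c(F)c3)[nH]n2)cc(OC)c1OC`) differs from compound 3 in one place: 3,4-difluorophenyl in place of 3,4-dichlorophenyl on a carbonyl carbon. Among the compounds with values here, no measured pair exchanges chlorine for fluorine on that aryl group, so the direction rests only on the size of the step from compound 1. Since compound 3 already sits at the top, a downward step a number 39 percentage points lower from compound 3 to compound 4 (beyond the scatter) is expected, and compound 4 is estimated at 10%, between -60% and 60%.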

Compound 4, a percentage reported as activity, at one concentration (the size of the read-out at that concentration, not a potency): 13%
For compound 4 the middle estimate is 3 percentage points below the measured one; low and high end bracket the measured number.
By their numbers in this assay, from the lowest: compound 1; then compound 2; then compound 4; then compound 3.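

In this assay, exchanging only the halogens on the aryl group gives a number 36 percentage points lower from compound 3 to compound 4 (beyond the scatter), so this position responds to the identity of the halogen and not just to the loss of the 4-aminophenyl group. Compound 4 nevertheless remains far from the amine-bearing analogue, with a number 99 percentage points higher from compound 1 to compound 4 (beyond the scatter). No measurement offered here accounts for either step. The compounds shown leave open whether 3,4-dibromophenyl would continue the change seen from fluorine to chlorine. They also leave open whether a 4-hydroxyphenyl or 4-dimethylaminophenyl group would behave like 4-aminophenyl.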